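The compounds below may be only part of what the source reports. "The series", "measured", "known", "first", "only" and "open" are said of these compounds alone.

Compound 1 `O=C(Nc1cccc(S(=O)(=O)C2CCCC2)c1)c1cccnc1N1CCCCC1` and compound 2 `CC(C)(C)NS(=O)(=O)c1cccc(NC(=O)c2cccnc2N2CCC3(CC2)CC3)c1` share a core and have both been run in an ADME assay on microsomes from liver (Homo sapiens) for metabolic stability, read by LC-MS, with a stated time of 40 min, tested at 0.5 uM; on this read-out higher numbers stand for fast clearance and lower numbers for slow clearance. For compound 1 the result in this assay is a limit, > 399 mL.min-1.g-1. For compound 2 the result is likewise a limit, > 399 mL.min-1.g-1. Thus (the limit of > 399 mL.min-1.g-1 in this assay, at which 2 of the 2 values shown sit), so no numbered step can be drawn from them. Compound 3 `CC1(C)CCN(c2ncccc2C(=O)Nc2cccc(S(=O)(=O)C3CCCC3)c2)CC1` has not yet been measured; it differs from compound 1 by 4,4-dimethylpiperidin-1-yl in place of piperidin-1-yl on an aromatic carbon. With no measured step shown, the expected step that the limit leaves unreadable from compound 1 to compound 3 is small, likely within the scatter. Compound 3 is estimated at 450 mL.min-1.g-1, between 180 mL.min-1.g-1 and 1000 mL.min-1.g-1.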

Compound 3, intrinsic clearance in microsomes: > 399 mL.min-1.g-1
Compound 3: a limit, no number; the forecaster's own chance of this, stated with the estimate: 70%; the middle value lies beyond the limit too.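

No step can be read from compound 1 to compound 3, since both results in this assay are limits: the limit of > 399 mL.min-1.g-1 in this assay, at which 3 of the 3 values shown sit.

The compounds shown leave open whether 4,4-dimethylpiperidin-1-yl in place of piperidin-1-yl alters clearance at all, and how large any such step would be.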